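This account rests on a few compounds, and the source may have more. Where it says the series, first, only, none or still open, it means among the compounds named here.

Within the data shown here, compound 3 `COc1ccc(/C=C\c2cc(OC)c(OC)c(OC)c2)cc1OCc1ccc(CN[C@H](C(=O)O)[C@@H](C)O)cc1` is one of three compounds measured in a functional assay on HeLa cells (Homo sapiens) for antiproliferative activity, read by CCK-8 assay, with a stated time of 48 h; a lower number here means a stronger inhibitor, a higher number a weaker inhibitor. For compound 3 the assay reports only a limit, > 10000 nM. Compound 1 `COc1ccc(/C=C\c2cc(OC)c(OC)c(OC)c2)cc1OCc1ccc(CN[C@H](C(=O)O)[C@H](C)O)cc1` has the same atoms and bonds as compound 3 and differs only in the configuration drawn at one stereocentre, and for compound 1 the assay likewise reports only a limit, > 10000 nM. Compound 2 `COc1ccc(/C=C\c2cc(OC)c(OC)c(OC)c2)cc1OCc1ccc(CN2CC(C(=O)O)C2)cc1` carries 3-carboxyazetidin-1-yl on the saturated chain carbon bound to an aromatic carbon, and in this assay compound 2 gives 6500 nM. The steps of an at least 1.5-fold lower number from compound 1 to compound 2 (0.18 log units; that floor lies within the scatter) and an at least 1.5-fold higher number from compound 2 to compound 3 (0.18 log units; that floor lies within the scatter) are floors only, and a step that the two limits leave unreadable from compound 1 to compound 3 cannot be read, because of the limit of > 10000 nM in this assay, at which 2 of the 3 values shown sit. Compound 4 `COc1ccc(/C=C\c2cc(OC)c(OC)c(OC)c2)cc1OCc1ccc(CO)cc1` has not yet been measured. The change from compound 3 to compound 4 is hydroxy in place of (1-carboxy-2-hydroxypropyl)amino on a saturated chain carbon bound to an aromatic carbon. Among the measured compounds shown here, no measured step exchanges the whole (1-carboxy-2-hydroxypropyl)amino group for hydroxy, so the measured steps give no direct guide; compound 2 alone shows that a different group at that position yields a number within the assay's range. Compound 4 is therefore expected at 2000 nM, between 200 nM and 10000 nM, an expected step of an at least 5.0-fold lower number from compound 3 to compound 4 (0.69 log units; beyond the scatter).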

Compound 4, half-maximal inhibitory concentration: 7600 nM
Compound 4: the middle estimate sits 3.8-fold (0.58 log units) below what was measured, and the stated range covers the measured number.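

On the saturated chain carbon bound to an aromatic carbon, hydroxy now gives a measured number in this assay and the exchange for 3-carboxyazetidin-1-yl is a 1.2-fold higher number from compound 2 to compound 4 (0.07 log units; within the scatter) so the two groups are not separated here. Set against (1-carboxy-2-hydroxypropyl)amino, the same hydroxy yields only floors (an at least 1.3-fold lower number from compound 3 to compound 4 (0.11 log units; that floor lies within the scatter) and an at least 1.3-fold lower number from compound 1 to compound 4 (0.11 log units; that floor lies within the scatter)) and neither floor goes beyond the scatter. Compound 4 thus shows that the group at this place can shrink to 1 heavy atom and still give a number that compound 2 cannot be told apart from.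

How far compound 1 and compound 3 lie from compound 4, or from each other, cannot be read, because both sit at a limit: the limit of > 10000 nM in this assay, at which 2 of the 4 values shown sit. On these data alone, what a primary amine or a longer chain ending in a carboxylic acid would give at this place also stays open.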